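Fluoroethoxy Variant of an Anilide Translocator Protein Ligand

This account rests on a few compounds, and the source may have more. Where it says the series, first, only, none or still open, it means among the compounds named here.

Compound 1 `CC(=O)N(Cc1ccccc1)c1cc(C)cc(C)c1`: 1260 nM in an assay on HEK293 cells for displacement of a labelled ligand from Translocator protein (Homo sapiens), read by scintillation counting, with a stated time of 90 min; a higher number here means a weaker inhibitor, a lower number a stronger inhibitor
Compound 2 `COc1ccc(CN(C(C)=O)c2cc(C)cc(C)c2)cc1`: 2790 nM in this assay
Compound 3 `CCN(CC)C(=O)CN(Cc1ccccc1)c1cc(C)cc(C)c1`: 4260 nM in this assay

Compound 3 stands highest of the three in this assay: against compound 1 the step is a 3.4-fold higher number from compound 1 to compound 3 (0.53 log units; beyond the scatter), while its value and that of compound 2 lie within the scatter. Compound 4 `CCN(CC)C(=O)CN(Cc1ccc(OCCF)cc1)c1cc(C)cc(C)c1` differs from compound 3 by 2-fluoroethoxy in place of hydrogen on an aromatic carbon, sitting para to a large group. Going by the values given here, the one measured step that bears on this change is a 2.2-fold higher number from compound 1 to compound 2 (0.35 log units; beyond the scatter), where methoxy in place of hydrogen on an aromatic carbon gave a modestly higher number. A modest rise in this assay is therefore expected for compound 4, a step of about a 1.8-fold higher number from compound 3 to compound 4 (0.25 log units; within the scatter). Compound 4 is estimated at 7500 nM, with a range from 3000 nM to 18000 nM.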

Compound 4, inhibition constant: > 10000 nM
Compound 4: no number, only a limit (the forecaster's own chance of this, stated with the estimate: 10%); middle value at least 1.3-fold (0.12 log units) away from the limit.
By their numbers in this assay, from the lowest: compound 1; then compounds 2 and 3 (each within the scatter of the next). At a limit, above all of these: compound 4.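

Compound 4 gives > 10000 nM in this assay, which is a limit and not a number. The step, an at least 2.3-fold higher number from compound 3 to compound 4 (0.37 log units; beyond the scatter), shows that an ether at this place, para to a large group, raises the number with the diethylcarbamoylmethyl group on the nitrogen as well, not only with the acetyl group of compound 2. Its full size cannot be read, so it cannot be set against the methoxy step.

The compounds shown leave open whether the fluorine plays any part, which a plain ethoxy on compound 3 would test. They also leave open how a hydroxyl or an amine at this place would read.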